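The source may report more compounds than this note shows. Statements on the series, on what has been measured and on what is new or still open speak of the compounds shown alone.

Measured so far:
compound 1 `[SeH]c1nc(NCc2ccccc2)c2cccnc2n1`: 33100 nM
compound 2 `CSc1nc(NCCCCCO)c2cccnc2n1`: > 100000 nM

In a functional assay on HT-29 cells (Homo sapiens) for cytotoxicity, read by MTT assay, with a stated time of 72 h (on this read-out higher numbers stand for weaker inhibition of growth and lower numbers for stronger inhibition of growth), compound 1 gives 33100 nM. Compound 2 gives only > 100000 nM, which is a limit of the assay and not a number. It sits at the limit of > 100000 nM in this assay, at which 1 of the 2 values shown sits, so no number places it. Compound 3 `CSc1nc(NCc2ccccc2)c2cccnc2n1` is not yet measured; it differs from compound 2 by phenyl in place of 4-hydroxybutyl on a saturated chain carbon bound to a nitrogen on an aromatic ring. Among the measured compounds shown here, no measured step of this kind exists, so the expectation rests on compound 1, which carries the same phenyl and gives 33100 nM. Compound 3 is expected to give about 40000 nM, within 12000 nM to 100000 nM. That estimate means an expected step toward stronger growth inhibition, an at least 2.5-fold lower number from compound 2 to compound 3 (0.39 log units; beyond the scatter), in this assay.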

Compound 3, concentration for total growth inhibition: > 100000 nM
Compound 3 was reported as a limit; the forecaster's own chance of this, stated with the estimate: 35%; middle value at least 2.5-fold (0.39 log units) from the limit.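

In this assay, a methylthio group in place of the selenium atom on an aromatic carbon, with the phenyl unchanged, gives an at least 3.0-fold higher number from compound 1 to compound 3 (0.48 log units; beyond the scatter). Among the compounds shown here, this is the first readable change in the set, and it points to weaker growth inhibition at this position. The value of compound 3 is a limit, and with the limit of compound 2 it leaves the phenyl for 4-hydroxybutyl step unreadable: the limit of > 100000 nM in this assay, at which 2 of the 3 values shown sit.

On these data alone, it remains open whether the selenium atom would keep a measurable value alongside 4-hydroxybutyl. As far as these compounds go, it is also open how an amine or a thiol on that aromatic carbon would read in this assay.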